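Heteroaryl amine exchange on the shared core

The compounds below may be only part of what the source reports. "The series", "measured", "known", "first", "only" and "open" are said of these compounds alone.

Measured so far:
compound 1 `Cc1ccc(CNC(=O)c2cccc(C(C)Oc3cccnc3Nc3nccs3)c2)cc1`: 15300 nM in a functional assay on NCI-H3122 cells (Homo sapiens) for antiproliferative activity, read by MTT assay, with a stated time of 48 h; a lower number here means a stronger inhibitor, a higher number a weaker inhibitor
compound 2 `Cc1ccc(CNC(=O)c2cccc(C(C)Oc3cccnc3Nc3ncc(C)s3)c2)cc1`: 8500 nM in this assay

Compound 2 holds the lower of the two numbers, but the step of a 1.8-fold lower number from compound 1 to compound 2 (0.26 log units; within the scatter) stays within the scatter, so no order between compound 1 and compound 2 is claimed.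

Compound 3 `Cc1ccc(CNC(=O)c2cccc(C(C)Oc3cccnc3Nc3nncs3)c2)cc1` differs from compound 2 by 1,3,4-thiadiazol-2-yl in place of 5-methyl-1,3-thiazol-2-yl on a nitrogen on an aromatic ring. Among the compounds with values here, the only measured step that bears on this change is a 1.8-fold lower number from compound 1 to compound 2 (0.26 log units; within the scatter), which covers the methyl alone and was within the scatter. Within the data shown here, the exchange of a ring carbon for a ring nitrogen has no counterpart among the measured compounds, so nothing is known about its effect here.

Because a 1.8-fold lower number from compound 1 to compound 2 (0.26 log units; within the scatter) was within the scatter, compound 3 is expected to land near compound 1 and compound 2 in this assay. The estimated step of a 1.4-fold higher number from compound 2 to compound 3 (0.15 log units; within the scatter) is expected to remain within the scatter. Compound 3 is estimated at 12000 nM, with a range from 5000 nM to 30000 nM.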

Compound 3, half-maximal inhibitory concentration: 20800 nM
Compound 3: the middle estimate sits 1.7-fold (0.24 log units) below what was measured; the measured number falls inside the stated range.
By their numbers in this assay, from the lowest: compounds 2, 1 and 3 (each within the scatter of the next, the first and the last beyond it).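

In this assay, the group on a nitrogen on an aromatic ring gives its first step beyond the scatter, a 2.4-fold higher number from compound 2 to compound 3 (0.39 log units; beyond the scatter), with 1,3,4-thiadiazol-2-yl in place of 5-methyl-1,3-thiazol-2-yl. The matching step without the methyl, a 1.4-fold higher number from compound 1 to compound 3 (0.13 log units; within the scatter), stays within the scatter, so the ring exchange alone shows no separable effect at this position, and the modest gap appears only between the two ends of the series. No measurement at hand accounts for that gap. Still open, on these data alone, is whether 5-methyl-1,3,4-thiadiazol-2-yl would track compound 2 or compound 3, which would separate the methyl from the ring exchange. Also open, as far as these compounds go, is how a longer chain such as ethyl, or an amine, on the five-membered ring would read.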